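The source may report more compounds than this note shows. Statements on the series, on what has been measured and on what is new or still open speak of the compounds shown alone.

Measured so far:
compound 1 `CC(C)(C)N(NC(=O)c1ccc(Cl)cc1)C(=O)c1ccccc1Cl` — 115 nM
compound 2 `CCc1ccc(C(=O)NN(C(=O)c2ccccc2)C(C)(C)C)cc1` — 4.9 nM

In an assay on cells for agonist activity at ecdysone receptor (Bombyx mori), read by a luciferase reporter, with a stated time of 24 h (on this read-out lower numbers stand for an effect already at smaller amounts and higher numbers for an effect only at larger amounts of compound), compound 2 gives 4.9 nM, the lowest of the two numbers; compound 1 gives 115 nM, a gap beyond the scatter. Within the data shown here, no two measured compounds differ in one place, so no single step is known.

Compound 3 `CCc1ccc(C(=O)NN(C(=O)C2CCCCC2)C(C)(C)C)cc1` is not yet measured. It differs from compound 2 by cyclohexyl in place of phenyl on a carbonyl carbon. Among the measured compounds shown here, no measured pair shows what this change does here. A loss is expected, a step of a 12-fold higher number from compound 2 to compound 3 (1.09 log units; beyond the scatter) upward beyond the scatter. For compound 3 in this assay the estimate is 60 nM, with a range from 10 nM to 400 nM.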

Compound 3, half-maximal effective concentration: 9330 nM
Compound 3: middle estimate off by 160-fold (2.19 log units), on the low side, and the stated range ends below it.
By their numbers in this assay, from the lowest: compound 2; then compound 1; then compound 3.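

In this assay the carbonyl-bound ring proves to be a sensitive position: cyclohexyl in place of phenyl gives a 1900-fold higher number from compound 2 to compound 3 (3.28 log units; beyond the scatter). Both rings are six-membered, carbon-only and have the same heavy-atom count, so within this pair, the non-aromatic ring is far from an equal replacement for the aromatic one. No available evidence bears on what lies behind this loss.

On these data alone, whether a pyridyl ring, a cyclohexenyl ring or a smaller cyclopentyl ring would stay nearer to compound 2 remains open. Also open, as far as these compounds go, is whether the same change costs as much with a group other than ethyl on the other ring.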